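A Trifluoromethyl Step Under a Shared Assay Limit

The compounds below may be only part of what the source reports. "The series", "measured", "known", "first", "only" and "open" are said of these compounds alone.

Compound 2 `Cc1cc(NC(=O)Nc2cccc(F)c2)c2ccccc2n1` is the starting point, and in an ADME assay on HEK293 cells (Homo sapiens) for cytotoxicity, with a stated time of 72 h (a higher number here means that more compound is needed for the effect, a lower number that less compound is needed), compound 2 gives > 25000 nM, which is a limit and not a number. Its position can therefore be described only by that limit. Compound 1 `Cc1cc(NC(=O)Nc2cccc(C(N)=O)c2)c2ccccc2n1` gives > 25000 nM in this assay, and this too is a limit. Compound 3 `COc1ccc(NC(=O)Nc2cc(C)nc3ccccc23)cc1F` gives > 25000 nM in this assay, again a limit. Together the series shows (the limit of > 25000 nM in this assay, at which 3 of the 3 values shown sit).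

Compound 4 `Cc1cc(NC(=O)Nc2cccc(C(F)(F)F)c2)c2ccccc2n1` has not yet been measured. It differs from compound 2 at one place (trifluoromethyl in place of fluoro on an aromatic carbon), with trifluoromethyl in place of fluoro on an aromatic carbon, meta to a large group.

For the measured compounds named here, two measured steps bear on this change, and neither has a readable size. Going by the values given here, the first is a step that the two limits leave unreadable from compound 1 to compound 2, which also replaces the fluoro position's group. The second is a step that the two limits leave unreadable from compound 2 to compound 3, which changes the same ring at another carbon. Neither step gives a size or direction to carry over, so no shift beyond the scatter is expected. The expected change is a number no higher from compound 2 to compound 4 (the limit leaves the size open). A further limit result would be the most likely report. For compound 4 the estimated value is 25000 nM, with an expected range from 12000 nM to 50000 nM.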

Compound 4, half-maximal effective concentration: 16000 nM
Compound 4: the middle estimate sits 1.6-fold (0.19 log units) above what was measured; measured number inside the range.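

For the compounds shown here, with trifluoromethyl on this aromatic carbon, compound 4 gives 16000 nM in this assay, the first actual number and the first reading at this position that is not a limit. The other compounds stay at a limit of the assay, which is not a number: the limit of > 25000 nM in this assay, at which 3 of the 4 values shown sit. Trifluoromethyl in place of fluoro gives an at least 1.5-fold lower number from compound 2 to compound 4 (0.19 log units; that floor lies within the scatter), and trifluoromethyl in place of carbamoyl gives an at least 1.5-fold lower number from compound 1 to compound 4 (0.19 log units; that floor lies within the scatter), so each step has only a floor, and that floor lies within the scatter, which means that neither step establishes a real shift at this carbon.

From the compounds shown here alone, the true size of both steps stays open, and the steps among compound 1, compound 2 and compound 3 cannot be read. The compounds shown also leave open whether a nitrile, a chlorine atom, an amine or a longer chain on this same carbon would give a number in this assay or stay at the limit, and whether trifluoromethyl would give a number on the core of compound 3.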